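Adding a Third Methoxy Group: Expected Cytotoxicity

The source may hold more compounds than are shown below. What is called first, only, known or untested is meant among the compounds shown, and "the series" means these compounds.

Compound 1, `COc1ccc(/C=C/C(=O)/C=C/C2=C(C)CCCC2(C)C)cc1`: in a functional assay on Hep cells (Homo sapiens) for cytotoxicity, read by sulforhodamine B assay, with a stated time of 48 h (a lower number here means a stronger inhibitor, a higher number a weaker inhibitor), compound 1 reaches only the limit > 100000 nM (the limit of > 100000 nM in this assay, at which 1 of the 2 values shown sits).
Compound 2, `COc1ccc(/C=C/C(=O)/C=C/C2=C(C)CCCC2(C)C)cc1OC`: in this assay compound 2 gives 72400 nM.

Compound 2 holds the only number shown. Among the compounds with values here, the single measured step, an at least 1.3-fold lower number from compound 1 to compound 2 (0.14 log units; that floor lies within the scatter), also put a methoxy on an aromatic carbon, and its floor sits within the scatter. Compound 3, `COc1cc(/C=C/C(=O)/C=C/C2=C(C)CCCC2(C)C)cc(OC)c1OC`, repeats that kind of change: methoxy in place of hydrogen on an aromatic carbon. That one step bears on it, so a further lowering is expected, though possibly not beyond the scatter. For compound 3 the estimate is 40000 nM, within 12000 nM to 100000 nM, a step of a 1.8-fold lower number from compound 2 to compound 3 (0.26 log units; within the scatter) expected.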

Compound 3, half-maximal inhibitory concentration: 45500 nM
Beside the measured number, compound 3's estimate is 1.1-fold (0.06 log units) below it; the measured number falls inside the stated range.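

In this assay, within the data shown here, the new step, a 1.6-fold lower number from compound 2 to compound 3 (0.20 log units; within the scatter), is the first that joins two true numbers, so its size can be read directly. A methoxy placed here, ortho to a methoxy group, therefore gives a change that stays inside the scatter. Compound 1 remains a limit, so the earlier step offers only a floor: the limit of > 100000 nM in this assay, at which 1 of the 3 values shown sits.

The compounds shown leave open whether a different group at this same place, such as an amine, a hydroxyl or a longer ethoxy chain, would move the number beyond the scatter.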